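This account rests on a few compounds, and the source may have more. Where it says the series, first, only, none or still open, it means among the compounds named here.

Compound 1 `Cc1cn2cc(-c3cc4ccc(N5CCN(C)CC5)cc4c(=O)o3)nc2cn1`: in an ADME assay on the whole organism (Rattus norvegicus, strain Sprague-Dawley) for pharmacokinetics, with a stated time of 6 h, at a dose of 10 mg/kg by the oral route (on this read-out lower numbers stand for lower exposure and higher numbers for higher exposure at the dose given), compound 1 gives < 10 ng.h/mL, which is a limit of the assay and not a number.
Compound 2 `Cc1cn2cc(-c3cc4ccc(N5CCN(C)CC5)cc4c(=O)o3)nc2c(C)n1`: in this assay compound 2 gives 790 ng.h/mL.
Compound 3 `Cc1cn2nc(-c3cc(=O)n4cc(N5CCN(C)CC5)ccc4n3)cc2cn1`: in this assay compound 3 gives < 10 ng.h/mL, which is also a limit and not a number.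

Two of the three readings sit at the limit of < 10 ng.h/mL in this assay, at which 2 of the 3 values shown sit. Compounds 1 and 2 share a core and differ by methyl in place of hydrogen on an aromatic carbon, and this single change gives an at least 79-fold higher number from compound 1 to compound 2 (1.89 log units; beyond the scatter). Compound 3 has a different core; how the two cores differ is not broken down here. Compound 4 `Cc1cn2nc(-c3cc(=O)n4cc(N5CCN(C)CC5)ccc4n3)cc2c(C)n1` carries the same change on the core of compound 3, namely (methyl in place of hydrogen on an aromatic carbon), with the place described in the same words as for compound 2. Compound 4 is therefore expected to show a step of about an at least 30-fold higher number from compound 3 to compound 4 (1.47 log units; beyond the scatter), an expectation that rests on the large step of an at least 79-fold higher number from compound 1 to compound 2 (1.89 log units; beyond the scatter), though the core of compound 3 is not the same. The estimate for compound 4 in this assay is 300 ng.h/mL, roughly between 30 ng.h/mL and 2000 ng.h/mL.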

Compound 4, area under the concentration-time curve: 2100 ng.h/mL
Compound 4: middle estimate off by 7.0-fold (0.85 log units), on the low side, and the stated range ends below it.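

Placing a methyl in place of hydrogen on an aromatic carbon of the core of compound 3 gives an at least 210-fold higher number from compound 3 to compound 4 (2.32 log units; beyond the scatter) in this assay. The change therefore carries from one core to the other in the same direction, with a large rise on both, but this is shown for these two cores only. It does not show how large either rise truly is or whether the two sizes match, since compound 1 and compound 3 each stand at a limit of the assay and not at a number: the limit of < 10 ng.h/mL in this assay, at which 2 of the 4 values shown sit.

The compounds shown leave open whether an ethyl group, a longer chain or an amine at the same place would raise exposure as well. They also leave open whether the methyl would have this effect on any further core.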